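A few compounds are considered here, and "the series" means these few. Any claim that something is new, unique, unknown or untested is made for them only; others in the source may bear on it.

Measured so far:
Compound 1, `N[C@H]1CC[C@H](CN(C[C@H]2Cc3ccccc3CN2)[C@H]2CCCc3cccnc32)CC1`: 280 nM
Compound 2, `NCC1CC1CN(C[C@H]1Cc2ccccc2CN1)[C@H]1CCCc2cccnc21`: 6.4 nM; 13 nM (2 entries)
Compound 3, `NCC1=C(CN(C[C@H]2Cc3ccccc3CN2)[C@H]2CCCc3cccnc32)CCCC1`: 230 nM

These three compounds share one core and differ only in the group carried on a saturated chain carbon bound to an amine nitrogen. Among the compounds with values here, in a functional assay on CCRF-CEM cells for antagonist activity at C-X-C chemokine receptor type 4 (Homo sapiens), read by calcium flux, with stated times of 25 min and 90 s (on this read-out lower numbers stand for stronger inhibition and higher numbers for weaker inhibition), compound 3 gives 230 nM, and compound 1 gives 280 nM; the single measured step between them, a 1.2-fold lower number from compound 1 to compound 3 (0.09 log units; within the scatter), is within the scatter, so the two sit together. Compound 2 gives 6.4 nM; 13 nM (2 entries) in this assay, and its repeats, (the several entries of compound 2 in this assay, 6.4 nM; 13 nM (2 entries)), show how far single measurements of this kind can spread.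

Compound 4, `C/C(CN(C[C@H]1Cc2ccccc2CN1)[C@H]1CCCc2cccnc21)=C(/F)CN`, has not yet been measured. It differs from compound 3 in one place: 3-amino-2-fluoro-1-methylprop-1-en-1-yl in place of 2-(aminomethyl)cyclohex-1-en-1-yl on a saturated chain carbon bound to an amine nitrogen. Within the data shown here, no measured step covers the loss of the ring or the entry of fluorine at this position. Among the measured compounds shown here, the only measured step that touches the same place, a 1.2-fold lower number from compound 1 to compound 3 (0.09 log units; within the scatter), was within the scatter and gives little guidance on direction. The step of a 1.4-fold lower number from compound 3 to compound 4 (0.16 log units; within the scatter) is therefore expected to be small, with no direction that clearly exceeds the scatter. Compound 4 is estimated at 160 nM, with a range from 40 nM to 650 nM.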

Compound 4, half-maximal inhibitory concentration: 1800 nM
For compound 4 the middle estimate is 11-fold (1.05 log units) below the measured one; the measured number lies above the stated range.
By their numbers in this assay, from the lowest: compounds 3 and 1 (each within the scatter of the next); then compound 4.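

The position is not indifferent to what it carries. The two groups built on a six-membered carbon ring, 4-aminocyclohexyl in compound 1 and 2-(aminomethyl)cyclohex-1-en-1-yl in compound 3, could not be told apart in this assay, but the open-chain 3-amino-2-fluoro-1-methylprop-1-en-1-yl group separates clearly from both, with a 7.8-fold higher number from compound 3 to compound 4 (0.89 log units; beyond the scatter) and a 6.4-fold higher number from compound 1 to compound 4 (0.81 log units; beyond the scatter). These two steps agree in direction and in rough size, so the weakening holds against either ring-bearing group and does not hang on a single comparison, although nothing shown gives a reason for it.

The change removes the ring and brings in fluorine in a single move, so the compounds shown cannot say which of the two carries the step, or whether both are needed. The 3-amino-1-methylprop-1-en-1-yl group, the same open chain with hydrogen in place of the fluorine, would help to pull the two apart, since it would differ from compound 4 only at the fluorine and would show what the open chain does alone.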